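Triazine series: fluoroalkoxy change at the aryl ether position

This account rests on a few compounds, and the source may have more. Where it says the series, first, only, none or still open, it means among the compounds named here.

Measured compounds:
compound 1 `CCN(CC)c1nc(Nc2ccc(C(=O)O)cc2)nc(OC(C(F)(F)F)C(F)(F)F)n1` — 900 nM
compound 2 `CCN(CC)c1nc(Nc2ccc3[nH]ncc3c2)nc(OC(C(F)(F)F)C(F)(F)F)n1` — 2800 nM

In an assay on cells for activation of Cystic fibrosis transmembrane conductance regulator (Homo sapiens), read by fluorescence, with stated times of 10 min and 12 s (a higher number here means that more compound is needed for the effect, a lower number that less compound is needed), compound 1 gives 900 nM, the lowest of the two numbers; compound 2 sits a 3.1-fold higher number from compound 1 to compound 2 (0.49 log units; beyond the scatter) away.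

The untested compound 3 `CCN(CC)c1nc(Nc2ccc(C(=O)O)cc2)nc(OCC(F)(F)C(F)F)n1` keeps the 4-carboxyphenyl amine of compound 1 and alters only the ether side chain: 2,2,3,3-tetrafluoropropyl in place of 2,2,2-trifluoro-1-(trifluoromethyl)ethyl on an oxygen on an aromatic ring. Among the compounds with values here, the one measured step, from compound 1 to compound 2, changes the amine substituent, not the ether, so it does not bear on this change. Within the data shown here, no measured pair informs the ether position; the expectation rests on compound 1 alone, and the change is taken as roughly neutral, so a step of a 1.3-fold higher number from compound 1 to compound 3 (0.12 log units; within the scatter) is expected, within the scatter. Compound 3 is therefore estimated at 1200 nM, with a range of 400 nM to 4000 nM.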

Compound 3, half-maximal effective concentration: 2500 nM
Compound 3: the middle estimate sits 2.1-fold (0.32 log units) below what was measured; measured number inside the range.
By their numbers in this assay, from the lowest: compound 1; then compounds 3 and 2 (each within the scatter of the next).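

In this assay, within the data shown here, the ether side chain proves to be a responsive position: with the 4-carboxyphenyl amine held fixed, 2,2,3,3-tetrafluoropropyl in place of 2,2,2-trifluoro-1-(trifluoromethyl)ethyl gives a 2.8-fold higher number from compound 1 to compound 3 (0.44 log units; beyond the scatter) and this is the first reading at this position, the earlier step having changed only the amine substituent. The change lowers the fluorine count and the heavy-atom count together, so this single pair does not separate one from the other. Nothing available bears on why the number moves.

Open, going by these compounds, is whether the same ether change gives a similar step with the 1H-indazol-5-yl amine of compound 2. Also open, on these data alone, is how a plain ethyl group, a longer fluorinated chain on the oxygen, or an amine in place of the ether would read.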